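A few compounds are considered here, and "the series" means these few. Any claim that something is new, unique, unknown or untested is made for them only; others in the source may bear on it.

Compound 1 `COc1cc(/C=C/C(=O)/C=C/c2nc3c(C)c(C)ccc3n2C)ccc1O`: 31900 nM
Compound 2 `COc1ccc(/C=C/C(=O)/C=C/c2nc3cc(C)ccc3n2C)cc1O`: 7700 nM
Compound 3 `COc1ccc(/C=C/C(=O)/C=C/c2nc3c(C)cccc3n2C)cc1O`: 25400 nM

All three values come from a functional assay on NCI-H460 cells (Homo sapiens) for cytotoxicity, read by MTT assay, with a stated time of 48 h; on this read-out higher numbers stand for weaker inhibition and lower numbers for stronger inhibition. In this assay, compound 3 gives 25400 nM, within the usual scatter of compound 1 at 31900 nM. Neither of these two can be ranked above the other. Compound 2 has the lowest number at 7700 nM, and its gap to each of the other two lies beyond the scatter, so it is the most potent of the three.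

The next compound is compound 4 `COc1ccc(/C=C/C(=O)/C=C/c2nc3c(C)c(C)ccc3n2C)cc1O`. It differs from compound 3 by one small change: methyl in place of hydrogen on an aromatic carbon. In words, a methyl replaces a hydrogen on an aromatic carbon, ortho to a methyl group.

Among the compounds with values here, no two measured compounds differ in only one place, so no measured step shows what such a change does here. The expectation is therefore modest, with no shift beyond the scatter. It starts from compound 3 at 25400 nM, while the range stays wide since compound 2 at 7700 nM shows that these numbers can spread.

The expected change is a 1.2-fold lower number from compound 3 to compound 4 (0.06 log units; within the scatter). For compound 4 the estimated value is 22000 nM, with an expected range from 9000 nM to 50000 nM.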

Compound 4, half-maximal inhibitory concentration: 7300 nM
Compound 4: middle estimate off by 3.0-fold (0.48 log units), on the high side; measured number outside the range, below it.
By their numbers in this assay, from the lowest: compounds 4 and 2 (each within the scatter of the next); then compounds 3 and 1 (each within the scatter of the next).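

In this assay, placing a methyl on the aromatic carbon ortho to the methyl group of compound 3 gives a 3.5-fold lower number from compound 3 to compound 4 (0.54 log units; beyond the scatter), the first measured sign that this single ring carbon can shift the number when the rest of the molecule stays fixed. The other methyl in the same kind of change behaves differently: adding it gives a 1.1-fold lower number from compound 2 to compound 4 (0.02 log units; within the scatter), so here the extra methyl leaves no shift that can be told from the scatter, and a methyl's effect in this pair of compounds depends on which ring carbon carries it. The phenyl end matters as well, since with the dimethyl-substituted core held constant, 3-hydroxy-4-methoxyphenyl in place of 4-hydroxy-3-methoxyphenyl gives a 4.4-fold lower number from compound 1 to compound 4 (0.64 log units; beyond the scatter), a shift that compounds differing in several places could not isolate.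

Nothing measured here accounts for why these shifts occur. From the compounds shown here alone, it also remains open whether a group other than methyl on this aromatic carbon, such as an ethyl, a methoxy or an amine, would lower the number further or lose the gain.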